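This account rests on a few compounds, and the source may have more. Where it says the series, first, only, none or still open, it means among the compounds named here.

Among the measured compounds shown here, in an ADME assay on microsomes from liver (Rattus norvegicus) for metabolic stability, read by LC-MS, with a stated time of 1 h, at 37 degrees C, tested at 4 uM (a lower number here means that less of the compound is left, a higher number that more of the compound is left), compound 1 (`O=C1c2ccc(OCc3cccc(-c4ccccc4)c3)cc2CN1C1CCCC1`) gives 38% and compound 2 (`COc1ccc(-c2cccc(COc3ccc4c(c3)CN(C3CCCC3)C4=O)c2)cc1C(=O)O`) gives 84%, which makes compound 2 the higher of the two numbers known so far. Compound 3 (`O=C(O)c1cc(F)cc(-c2cccc(COc3ccc4c(c3)CN(C3CCCC3)C4=O)c2)c1`) differs from compound 2 in one place: 3-carboxy-5-fluorophenyl in place of 3-carboxy-4-methoxyphenyl on an aromatic carbon. Here 3-carboxy-5-fluorophenyl stands in place of 3-carboxy-4-methoxyphenyl on an aromatic carbon. For the measured compounds named here, the one measured step that bears on this is a number 46 percentage points higher from compound 1 to compound 2 (beyond the scatter), seen with 3-carboxy-4-methoxyphenyl in place of phenyl. That step does not show how much of the rise goes with the carboxy part and how much with the methoxy part. The carboxy part stays and the methoxy part goes, so only a small downward move, not beyond the scatter, is expected: a number 6 percentage points lower from compound 2 to compound 3 (within the scatter). The estimate for compound 3 is 78%, with an expected range from 60% to 92%.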

Compound 3, percent of the compound remaining: 55%
Beside the measured number, compound 3's estimate is 23 percentage points above it; the measured number lies below the stated range.
By their numbers in this assay, from the lowest: compound 1; then compound 3; then compound 2.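

In this assay, the exchange of 3-carboxy-4-methoxyphenyl for 3-carboxy-5-fluorophenyl gives a number 29 percentage points lower from compound 2 to compound 3 (beyond the scatter), so keeping the carboxy part does not by itself hold the number at this position, and the other group on that ring counts as well. Measured against plain phenyl, the fluorinated ring still gives a number 17 percentage points higher from compound 1 to compound 3 (beyond the scatter), a smaller rise than the one seen with 3-carboxy-4-methoxyphenyl, though both rings that carry the carboxy part stand above phenyl. No measurement at hand explains why the number moves with these changes.

The compounds shown leave open how much of the fall goes with losing the methoxy group and how much with gaining the fluorine, as both change in one step. Also open, as far as these compounds go, is how a ring carrying only the methoxy group, or a primary amide instead of the carboxylic acid, would read.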